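The source may report more compounds than this note shows. Statements on the series, on what has been measured and on what is new or still open speak of the compounds shown alone.

Measured in a functional assay on HeLa cells (Homo sapiens) for inhibition, read by MTT assay, with a stated time of 48 h; on this read-out lower numbers stand for stronger inhibition and higher numbers for weaker inhibition:
Compound 1 `CCOC(=O)C1=C(N/N=C(/C(=O)Br)c2ccc(Br)cc2)Nc2[nH]nc(C)c2C1c1ccc(N(C)C)cc1`: 68500 nM
Compound 2 `CCOC(=O)C1=C(N/N=C(/Br)c2ccccc2)Nc2[nH]nc(C)c2C1c1ccc(N(C)C)cc1`: 75700 nM

Compound 2 stands level with compound 1. Among the compounds with values here, the only measured step, a 1.1-fold higher number from compound 1 to compound 2 (0.04 log units; within the scatter), does not separate them, so neither holds a distinct rank on these two numbers.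

The next compound is compound 3 `CCOC(=O)C1=C(N/N=C(/C(=O)Br)c2ccc(Cl)cc2)Nc2[nH]nc(C)c2C1c1ccc(N(C)C)cc1`. The change is a group of 12 heavy atoms (8 carbon, 1 nitrogen, 1 oxygen, 1 chlorine, 1 bromine; one six-membered aromatic ring of carbon only) in place of a group of 9 heavy atoms (7 carbon, 1 nitrogen, 1 bromine; one six-membered aromatic ring of carbon only), on an amine nitrogen. The step between compound 1 and compound 2 is the only measured one that bears on this change, as it exchanges groups of the same two sizes in the opposite direction. Within the data shown here, no measured compound carries chlorine, so that part of the change has no direct measurement behind it. Among the measured compounds shown here, with a 1.1-fold higher number from compound 1 to compound 2 (0.04 log units; within the scatter) as the only guide, no step beyond the scatter is expected in this assay, and no direction can be favoured with any confidence. The estimated step is a 1.1-fold lower number from compound 2 to compound 3 (0.03 log units; within the scatter). For compound 3 the expected value is 70000 nM, with an estimated range of 40000 nM to 120000 nM.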

Compound 3, half-maximal inhibitory concentration: 49300 nM
The estimate for compound 3 lay 1.4-fold (0.15 log units) above the measured number; low and high end bracket the measured number.
By their numbers in this assay, from the lowest: compounds 3, 1 and 2 (each within the scatter of the next).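

In this assay, within the data shown here, chloro in place of bromo on an aromatic carbon gives a 1.4-fold lower number from compound 1 to compound 3 (0.14 log units; within the scatter), the first comparison confined to the halogen on the aromatic ring, and the two compounds are not separated. On the amine nitrogen, the group of 12 heavy atoms in place of the group of 9 heavy atoms, now with chloro rather than bromo, gives a 1.5-fold lower number from compound 2 to compound 3 (0.19 log units; within the scatter), so among these three compounds neither halogen gives this larger group a number distinct from that of the smaller one. Among these compounds, no measurement on these compounds offers an account of how the values relate to structure.

The step from compound 2 to compound 3 adds a carbonyl and a chloro together, so their separate contributions remain unresolved. Also open is whether a group of another kind on the aromatic ring, such as methoxy, a carboxylic acid or an amine, would give a step beyond the scatter in this assay, since the compounds shown carry only halogens there.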